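A few compounds are considered here, and "the series" means these few. Any claim that something is new, unique, unknown or untested is made for them only; others in the source may bear on it.

Measured compounds:
Compound 1 `O=c1oc2c(O)cccc2cc1-c1ccccc1` — 4620 nM
Compound 2 `O=c1oc2c(O)c(O)ccc2cc1-c1ccccc1` — 2400 nM
Compound 3 `O=c1oc2c(O)cccc2cc1-c1ccc(O)c(O)c1` — 6200 nM

In an assay on CHO cells for displacement of a labelled ligand from adenosine receptor A1 (Homo sapiens), read by radioligand binding (on this read-out higher numbers stand for weaker inhibition and lower numbers for stronger inhibition), compound 1 gives 4620 nM. Compound 2 carries hydroxy in place of hydrogen on an aromatic carbon on the shared core; in this assay compound 2 gives 2400 nM, and the step is a 1.9-fold lower number from compound 1 to compound 2 (0.28 log units; within the scatter). Compound 3 gives 6200 nM in this assay; the difference between the core of compound 3 and the core of compound 1 is not broken down here.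

Compound 4 `O=c1oc2c(O)c(O)ccc2cc1-c1ccc(O)c(O)c1` is not yet measured. It differs from compound 3 by hydroxy in place of hydrogen on an aromatic carbon, the same change that takes compound 1 to compound 2, with the same surroundings at the place. Among the compounds with values here, the step expected from compound 3 to compound 4 in this assay is a 1.8-fold lower number from compound 3 to compound 4 (0.25 log units; within the scatter), resting on the single earlier step of a 1.9-fold lower number from compound 1 to compound 2 (0.28 log units; within the scatter), which itself lies within the scatter. The estimate for compound 4 in this assay is 3500 nM, expected between 1500 nM and 8000 nM.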

Compound 4, inhibition constant: 6280 nM
Compound 4: middle estimate off by 1.8-fold (0.25 log units), on the low side; low and high end bracket the measured number.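

In this assay, hydroxy in place of hydrogen on an aromatic carbon gives a 1.0-fold higher number from compound 3 to compound 4 (0.01 log units; within the scatter). Set beside the earlier step, the result on the two cores cannot be told apart: the same change on two cores in this assay, a 1.9-fold lower number (0.28 log units; within the scatter) from compound 1 to compound 2 and a 1.0-fold higher number (0.01 log units; within the scatter) from compound 3 to compound 4, 1.9-fold (0.29 log units) apart, within the scatter of two such steps. This gives no sign that the core alters the step, but each step lies within the scatter, so the pair shows neither a real effect of the change on either core nor that the change would carry to other cores in the series.

The compounds shown leave open whether another group at this place, such as methoxy, an amine or a carboxylic acid, would give a step beyond the scatter. From the compounds shown here alone, whether fluorine there would do so also remains open.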